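The source may report more compounds than this note shows. Statements on the series, on what has been measured and on what is new or still open speak of the compounds shown alone.

Measured in a functional assay on MCF7 cells (Homo sapiens) for antiproliferative activity, read by MTT assay, with a stated time of 72 h; on this read-out higher numbers stand for weaker inhibition and lower numbers for stronger inhibition
compound 1 `COc1cccc(Nc2nc3c(c(Oc4cccc(NC(=O)/C=C/C(C)C)c4)n2)CSCC3)c1` gives 21800 nM
compound 2 `CC(C)=CC(=O)Nc1cccc(Oc2nc(Nc3cccc(C#N)c3)nc3c2CSCC3)c1` gives > 50000 nM

For compound 2, > 50000 nM is a limit of the assay and not a number. Compound 3 `CC(C)/C=C/C(=O)Nc1cccc(Oc2nc(Nc3cccc(C#N)c3)nc3c2CSCC3)c1` carries 3-methylbut-1-en-1-yl in place of 2-methylprop-1-en-1-yl on a carbonyl carbon and is otherwise compound 2. Within the data shown here, the only number to lean on is compound 1 at 21800 nM in this series. A small expected move toward stronger inhibition in this assay is estimated, an at least 1.4-fold lower number from compound 2 to compound 3 (0.15 log units; that floor lies within the scatter) being its expected size, and a second limit remains possible. Compound 3 is estimated at 35000 nM with 15000 nM to 70000 nM as the expected range.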

Compound 3, half-maximal inhibitory concentration: 29600 nM
The estimate for compound 3 lay 1.2-fold (0.07 log units) above the measured number, and the stated range covers the measured number.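

Compound 2 gives only a limit, not a number, in this assay: the limit of > 50000 nM in this assay, at which 1 of the 3 values shown sits. On the carbonyl carbon, 3-methylbut-1-en-1-yl in place of 2-methylprop-1-en-1-yl gives a measurable value, with an at least 1.6-fold lower number from compound 2 to compound 3 (0.22 log units; that floor lies within the scatter), so the size of this change is known only as a floor. With 3-methylbut-1-en-1-yl held fixed, cyano in place of methoxy on an aromatic carbon gives a 1.4-fold higher number from compound 1 to compound 3 (0.13 log units; within the scatter).

As far as these compounds go, the full size of the step on the carbonyl carbon stays open. Also open, from the compounds shown here alone, is whether a longer chain or an amine there would give a step beyond the scatter.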